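Aminopyrimidine Isothiocyanates: From Compound 1 to Compound 3

The source may hold more compounds than are shown below. What is called first, only, known or untested is meant among the compounds shown, and "the series" means these compounds.

Compound 1, `CN(C)C(=O)c1cc2cnc(Nc3ccc(S(=O)(=O)NCCCN=C=S)cc3)nc2n1C1CCCC1`: 58.9%
Compound 2, `CN(C)C(=O)c1cc2cnc(Nc3ccc(C(=O)NCCCCCN=C=S)cc3F)nc2n1C1CCCC1`: -1.6%

Of the compounds shown here, two on a shared core have been measured in a functional assay on A549 cells (Homo sapiens) for inhibition, read by CCK-8 assay, with a stated time of 72 h, tested at 1 uM; a lower number here means a weaker effect, a higher number a stronger effect of the compound at the concentration tested. Compound 1 gives 58.9% and stands highest of the two numbers. Among the compounds with values here, its nearest neighbour, compound 2, gives -1.6%, a gap beyond the scatter; since the two compounds differ in more than one place, the pair shows only that the numbers lie far apart.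

Compound 3, `CN(C)C(=O)c1cc2cnc(Nc3ccc(NC(=O)CCCCCN=C=S)cc3)nc2n1C1CCCC1`, has not yet been measured. It differs from compound 1 by a group of 11 heavy atoms (7 carbon, 2 nitrogen, 1 oxygen, 1 sulfur; no ring) in place of a group of 10 heavy atoms (4 carbon, 2 nitrogen, 2 oxygen, 2 sulfur; no ring), on an aromatic carbon. The group that enters brings an amide in place of the sulfonamide and a longer chain carrying the isothiocyanate, on the aromatic carbon para to a large group.

Within the data shown here, no step between measured compounds is known that isolates this change. Among the measured compounds shown here, the only guide is that compound 2, which also carries an amide-linked, longer chain, gives -1.6%. On that slim basis a loss is expected from compound 1 to compound 3, estimated as a number 28.9 percentage points lower from compound 1 to compound 3 (beyond the scatter). Compound 3 is estimated to give 30% in this assay, within a wide range from -5% to 65%.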

Compound 3, a percentage reported as inhibition, at one concentration (the size of the read-out at that concentration, not a potency): 56.1%
Beside the measured number, compound 3's estimate is 26.1 percentage points below it, within the range that was stated.
By their numbers in this assay, from the lowest: compound 2; then compounds 3 and 1 (each within the scatter of the next).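

In this assay, within the data shown here, the first step at this position reads a number 2.8 percentage points lower from compound 1 to compound 3 (within the scatter) and so shows no difference that the assay can resolve. On the aromatic carbon para to a large group, the group of 11 heavy atoms with its amide and longer chain thus stands in for the group of 10 heavy atoms with its sulfonamide, and in this pair neither the sulfonamide nor the shorter chain proves necessary for a read-out of this size at the single concentration tested. Nothing available here explains why the two groups read alike.

The change alters the link and the chain length together, so a sulfonamide on the longer chain or an amide on the shorter chain would be needed to tell the two apart. From the compounds shown here alone, compound 2 is joined to neither of the other compounds by a change in one place, which leaves its low number unresolved, and it also remains open how the read-out would respond if an amine took the place of the isothiocyanate.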